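Side chain change from compound 2 to compound 3

The source may hold more compounds than are shown below. What is called first, only, known or untested is meant among the compounds shown, and "the series" means these compounds.

Measured values in an ADME assay on microsomes from liver (Homo sapiens) for metabolic stability, read by LC-MS, using NADPH, with a stated time of 120 min, tested at 1 uM (a lower number here means slower removal, a higher number faster removal of the compound), are:
compound 1 `CCC(O)CNC(=O)C[C@H](CCC1CCCCC1)NC(=O)c1cc(-c2c(OC)cccc2OC)n(CC(C)C)n1` gives 389 mL/min/kg
compound 2 `COC(=O)CN(C)C(=O)[C@H](CCc1ccccc1)NC(=O)c1cc(-c2c(OC)cccc2OC)n(CC(C)C)n1` gives 153 mL/min/kg

Compound 2 holds the lower of these two numbers, and its gap to compound 1 lies beyond the usual scatter. The next structure, compound 3 `COc1cccc(OC)c1-c1cc(C(=O)N[C@@H](CCc2ccccc2)CC(=O)NC2CCC2)nn1CC(C)C`, has not yet been measured. Its difference from compound 2 is (cyclobutylcarbamoyl)methyl in place of ((methoxycarbonyl)methyl)(methyl)carbamoyl on a saturated chain carbon bound to an amide-type nitrogen and a saturated chain carbon and it lies on a saturated chain carbon bound to an amide-type nitrogen and a saturated chain carbon.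

Going by the values given here, no measured pair differs in one place only, so this change has no direct precedent, and the gap between the two measured compounds cannot be assigned to any single group. The nearest reference is compound 1 at 389 mL/min/kg in this assay, which also carries an amide hydrogen in its side chain. A modest rise in this assay is therefore expected, of a size that may not clear the scatter. The estimate is a 1.5-fold higher number from compound 2 to compound 3 (0.18 log units; within the scatter) in this direction. Compound 3 is expected at 230 mL/min/kg in this assay, with an estimated range of 110 mL/min/kg to 450 mL/min/kg for the coming measurement.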

Compound 3, clearance: 347 mL/min/kg
The estimate for compound 3 lay 1.5-fold (0.18 log units) below the measured number, within the range that was stated.
By their numbers in this assay, from the lowest: compound 2; then compounds 3 and 1 (each within the scatter of the next).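

In this assay, going by these compounds alone, the swap of ((methoxycarbonyl)methyl)(methyl)carbamoyl for (cyclobutylcarbamoyl)methyl on a saturated chain carbon bound to an amide-type nitrogen and a saturated chain carbon gives a 2.3-fold higher number from compound 2 to compound 3 (0.36 log units; beyond the scatter), the first single-place step, and it shows that clearance responds to the group at this position while the shared core stays fixed. The change is a bundle rather than one clean edit: the methoxycarbonyl group leaves, a four-membered carbon ring enters, and the entering group carries an amide hydrogen that the leaving group lacks. No supporting measurement bears on what drives the step.

Which of these features carries the step remains open, as does whether the step would hold with the rest of the side chain altered. A methyl group on the amide nitrogen of the (cyclobutylcarbamoyl)methyl group would test the amide hydrogen on its own, while an isopropyl amide in place of the cyclobutyl amide would test the ring.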